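The source may hold more compounds than are shown below. What is called first, only, known or untested is meant among the compounds shown, and "the series" means these compounds.

In a functional assay on MCF7 cells (Homo sapiens) for antiproliferative activity, read by sulforhodamine B assay, with a stated time of 48 h (on this read-out higher numbers stand for weaker inhibition and lower numbers for stronger inhibition), compound 1 `COc1cccc(C=C(C(=O)/C=C/c2cccc(OC)c2OC)C(=O)/C=C/c2cccc(OC)c2OC)c1OC` gives 520 nM, and compound 2 `COc1cc(C=C(C(=O)/C=C/c2cccc(OC)c2OC)C(=O)/C=C/c2cccc(OC)c2OC)cc(OC)c1O` gives 460 nM. With only these two numbers available, compound 2 stands level with compound 1. Compound 3 `COc1cccc(/C=C/C(=O)C(=Cc2ccc(OC)c(OC)c2OC)C(=O)/C=C/c2cccc(OC)c2OC)c1OC` has not yet been measured. Its difference from compound 2 lies on a double-bonded chain carbon bound to a double-bonded chain carbon: 2,3,4-trimethoxyphenyl in place of 4-hydroxy-3,5-dimethoxyphenyl on a double-bonded chain carbon bound to a double-bonded chain carbon. In short, 2,3,4-trimethoxyphenyl takes the place of 4-hydroxy-3,5-dimethoxyphenyl.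

Going by the values given here, one measured step bears on this change, as it alters the group at the same place. That step is a 1.1-fold lower number from compound 1 to compound 2 (0.05 log units; within the scatter), so replacing 2,3-dimethoxyphenyl with 4-hydroxy-3,5-dimethoxyphenyl left the number within the scatter. Among the compounds with values here, no measured compound carries 2,3,4-trimethoxyphenyl at this place, so this single step is only a weak guide. A change no larger than the scatter is therefore expected in this assay, with no firm direction. The expected size is a 1.1-fold higher number from compound 2 to compound 3 (0.04 log units; within the scatter). For compound 3, the estimated value is 500 nM, with an expected range from 210 nM to 1200 nM.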

Compound 3, half-maximal inhibitory concentration: 380 nM
Estimate against measurement, compound 3: 1.3-fold (0.12 log units) above, and the stated range covers the measured number.
By their numbers in this assay, from the lowest: compounds 3, 2 and 1 (each within the scatter of the next).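

In this assay, going by these compounds alone, the place on a double-bonded chain carbon bound to a double-bonded chain carbon has now held three different substituted phenyl groups, and no step among them goes beyond the scatter. Putting 2,3,4-trimethoxyphenyl in place of 4-hydroxy-3,5-dimethoxyphenyl gives a 1.2-fold lower number from compound 2 to compound 3 (0.08 log units; within the scatter) even though the entering group has no hydrogen-bond donor and the leaving group has one, so across these compounds the number does not depend on that donor, and methoxy in place of hydrogen on an aromatic carbon gives a 1.4-fold lower number from compound 1 to compound 3 (0.14 log units; within the scatter) as well. Nothing available explains why these numbers lie so close together.

On these data alone, all three compounds carry methoxy groups on the phenyl ring at this place, so it remains open whether a dimethylamino group or a carboxylic acid on that ring would move the number beyond the scatter. Also open, as far as these compounds go, is what a change would do to the two 2,3-dimethoxyphenyl groups on the other chains, which all three compounds share.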